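Dimethylthiophene swap on the core of compound 2

The source may hold more compounds than are shown below. What is called first, only, known or untested is meant among the compounds shown, and "the series" means these compounds.

In a functional assay on cells (Cancer cell lines, Homo sapiens) for inhibition (a higher number here means a weaker inhibitor of growth, a lower number a stronger inhibitor of growth), compound 1 `Cc1cn2c(/C=N/Nc3ccccn3)c(-c3ccc(Cl)c([N+](=O)[O-])c3)nc2s1` gives 11500 nM, compound 2 `N=C(N)N/N=C/c1c(-c2cc(Cl)sc2Cl)nc2n1CCS2` gives 11200 nM and compound 3 `Cc1cc(-c2nc3sccn3c2/C=N/NC(=N)N)c(C)s1` gives 16600 nM. Compound 2 thus stands level with the other two: all three values lie within the scatter of one another, so no order can be read from them.

Compound 4 `Cc1cc(-c2nc3n(c2/C=N/NC(=N)N)CCS3)c(C)s1` keeps the core of compound 2 and carries 2,5-dimethylthiophen-3-yl in place of 2,5-dichlorothiophen-3-yl on an aromatic carbon. Among the measured compounds shown here, no measured pair isolates this change, so the data give no direct size for it.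

Compound 3 carries the same 2,5-dimethylthiophen-3-yl on a different core and gives 16600 nM, within the scatter of compound 2 at 11200 nM, so no shift beyond the scatter is expected in this assay. The estimated step is a 1.3-fold higher number from compound 2 to compound 4 (0.10 log units; within the scatter), expected to stay within the scatter. For compound 4 the expected value is 14000 nM, with an estimated range of 6500 nM to 30000 nM.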

Compound 4, concentration for 50% growth inhibition: 17000 nM
The estimate for compound 4 lay 1.2-fold (0.08 log units) below the measured number, within the range that was stated.
By their numbers in this assay, from the lowest: compounds 2, 1, 3 and 4 (each within the scatter of the next).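

In this assay the exchange on the core of compound 2 now has a direct size: a 1.5-fold higher number from compound 2 to compound 4 (0.18 log units; within the scatter). With the ring kept and only its two chlorines replaced by methyl groups, this position on the five-membered aromatic ring with 2 nitrogen shows no shift in growth inhibition beyond the scatter. Among the compounds shown here, this is the first single-place comparison, and the data offer no measurement that explains the result.

The compounds shown leave open whether any group at this aromatic carbon can move the number beyond the scatter, for instance a thiophene bearing a carboxylic acid or an amine. For the compounds shown here, they also leave open whether the same exchange reads alike on other cores, since no matched pair on a second core appears here.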